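The source may hold more compounds than are shown below. What is called first, only, known or untested is meant among the compounds shown, and "the series" means these compounds.

Measured so far: compound 1 `COc1ncnc2c1ncn2[C@@H]1O[C@H](COC(=O)c2ccc(C)cc2)[C@@H](OC(=O)c2ccc(C)cc2)[C@@H]1OC(=O)c1ccc(C)cc1`, < 5000 nM; compound 2 `COc1ncnc2c1ncn2[C@@H]1O[C@H](CO)[C@@H](OC(=O)c2ccccc2)[C@@H]1OC(=O)c1ccccc1`, 13000 nM.

In a physicochemical assay for solubility, in phosphate buffer (a lower number here means a less soluble compound, a higher number a more soluble compound), compound 1 gives only a limit, < 5000 nM, which is the limit of < 5000 nM in this assay, at which 1 of the 2 values shown sits. In this assay compound 2 gives a number, 13000 nM. Compound 3 `COc1ncnc2c1ncn2[C@@H]1O[C@H](CO)[C@@H](OC(=O)c2ccc(C)cc2)[C@@H]1OC(=O)c1ccc(C)cc1` is not yet measured; it differs from compound 1 by hydrogen in place of (4-methylphenyl)carbonyl on an oxygen on a saturated carbon. Among the compounds with values here, no step between measured compounds is available. Compound 2 already carries a hydroxymethyl at 13000 nM, and compound 3 carries the same hydroxymethyl with two (4-methylphenyl)carbonyl esters. An increase in solubility beyond the scatter is expected, an at least 1.6-fold higher number from compound 1 to compound 3 (0.20 log units; that floor lies within the scatter). Compound 3 is estimated at 8000 nM, range 3000 nM to 20000 nM.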

Compound 3, solubility: 5000 nM
The estimate for compound 3 lay 1.6-fold (0.20 log units) above the measured number; measured number inside the range.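

In this assay, hydrogen in place of (4-methylphenyl)carbonyl on an oxygen on a saturated carbon gives a number no lower from compound 1 to compound 3 (the limit leaves the size open). Compound 1 gives only a limit, < 5000 nM. The number for compound 3 stands exactly at that edge of the assay, so the change yields a readable value, but the size of the step cannot be read: the limit of < 5000 nM in this assay, at which 1 of the 3 values shown sits.

From the compounds shown here alone, how far this hydroxymethyl compound truly lies from compound 1 stays open. Also open, going by these compounds, is how an amine or a carboxylic acid in place of the hydroxymethyl would read.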